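A few compounds are considered here, and "the series" means these few. Any claim that something is new, unique, unknown or untested is made for them only; others in the source may bear on it.

In a functional assay on the whole organism with Mus musculus as the target, at a dose of 50 mg/kg by the intraperitoneal route (on this read-out lower numbers stand for less inhibition and higher numbers for more inhibition at the one dose given (going by the name of the read-out)), three compounds have been measured so far. Compound 1, `Cc1ccc(S(=O)(=O)N2C(=O)CCC2C(=O)NN)cc1`, gives 52.8%. Compound 2, `Cc1ccc(S(=O)(=O)N2C(=O)CCC2C(=O)NNc2ccccc2)cc1`, gives 64.3%. Compound 3, `O=C(NNc1ccccc1)C1CCC(=O)N1S(=O)(=O)c1ccc(Cl)c(Cl)c1`, gives 57.7%. Compound 1 differs from compound 2 by hydrogen in place of phenyl on an amine nitrogen, and this change brings a number 11.5 percentage points lower from compound 2 to compound 1 (beyond the scatter). The cores of compound 2 and compound 3 differ by 3,4-dichlorophenyl in place of 4-methylphenyl on a sulfonyl sulfur, a change that brings a number 6.6 percentage points lower from compound 2 to compound 3 (within the scatter). Compound 3 and compound 1 show values within the scatter of each other, so nothing can be said about their order.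

Compound 4, `NNC(=O)C1CCC(=O)N1S(=O)(=O)c1ccc(Cl)c(Cl)c1`, has not yet been measured. It differs from compound 3 by hydrogen in place of phenyl on an amine nitrogen. This is the same change that turns compound 2 into compound 1, and the place is described in the same words for both pairs; among the compounds shown it occurs twice in all. Among the measured compounds shown here, only one measured instance of it exists, so any expectation rests on a single step. In this assay the expected step is a number 11.7 percentage points lower from compound 3 to compound 4 (beyond the scatter), in line with the earlier measured step of a number 11.5 percentage points lower from compound 2 to compound 1 (beyond the scatter). Compound 4 is therefore expected to give about 46%, within a likely range from 34% to 58%. That expectation rests on compound 3 standing at 57.7% and on the earlier instance of the change having lowered the reading by a modest amount.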

Compound 4, a percentage reported as inhibition, in the whole organism at one dose (the size of the read-out at that dose, not a potency): 58.3%
Compound 4: middle estimate off by 12.3 percentage points, on the low side; measured number outside the range, above it.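

In this assay, putting hydrogen in place of phenyl on an amine nitrogen now gives a number 0.6 percentage points higher from compound 3 to compound 4 (within the scatter), whereas on the other core the same change gave a number 11.5 percentage points lower from compound 2 to compound 1 (beyond the scatter). Only the earlier step lies beyond the scatter, yet the two steps themselves cannot be told apart, so the series gives no firm sign that the core sets the size of this change: the same change on two cores in this assay, a number 11.5 percentage points lower (beyond the scatter) from compound 2 to compound 1 and a number 0.6 percentage points higher (within the scatter) from compound 3 to compound 4, 12.1 percentage points apart, within the scatter of two such steps. Among the compounds shown here, this does not show that the change carries over unaltered from one core to the other, nor that the 3,4-dichlorophenyl core cancels it, and with only two pairs, each read at a single dose, neither reading can be ruled out.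

Among the compounds shown, only phenyl and hydrogen stand on that amine nitrogen and only 4-methylphenyl and 3,4-dichlorophenyl stand on the sulfonyl sulfur, so it remains open how a benzyl or an acetyl group on the nitrogen, or a 4-methoxyphenyl group or a longer alkyl chain on the sulfur, would read. A further pair on a third core, such as one with 4-methoxyphenyl on the sulfur, would also be needed to say whether the change has a usual size in this series.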